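This account rests on a few compounds, and the source may have more. Where it says the series, first, only, none or still open, it means among the compounds named here.

Measured compounds:
compound 1 `Fc1ccc2c(-c3ccc4ccccc4n3)c[nH]c2c1Cl`, in an ADME assay on microsomes from liver (Homo sapiens) for metabolic stability, using NADPH, with a stated time of 40 min, tested at 2 uM (on this read-out higher numbers stand for a longer-lived compound and lower numbers for a shorter-lived compound), compound 1 gives 0.183 h
compound 2 `Cc1c(F)ccc2c(-c3ccc4ccccc4n3)c[nH]c12`, in this assay compound 2 gives 0.433 h
compound 3 `Clc1cc(Cl)c2[nH]cc(-c3ccc4ccccc4n3)c2c1`, in this assay compound 3 gives 2.57 h

Within the pair compound 1 and compound 2 the change is methyl in place of chloro on an aromatic carbon. In this assay this gives a 2.4-fold higher number from compound 1 to compound 2 (0.37 log units; beyond the scatter). Compound 3 stands highest of the three; the difference between its core and the core of compound 1 is not broken down here, and the values of compound 3 and compound 1 show a wide gap in favour of compound 3.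

Compound 4 `Cc1cc(Cl)c2[nH]cc(-c3ccc4ccccc4n3)c2c1` is not yet measured in this assay. It relates to compound 3 by methyl in place of chloro on an aromatic carbon. This is the same kind of change as from compound 1 to compound 2, not the same: there the methyl enters ortho to a fluoro group, ortho to a fused ring and meta to a fused ring; here it enters meta to a chloro group, meta to a fused ring and para to a fused ring.

The expectation for compound 4 is a 1.8-fold higher number from compound 3 to compound 4 (0.24 log units; within the scatter), resting on a 2.4-fold higher number from compound 1 to compound 2 (0.37 log units; beyond the scatter) and on the different surroundings. Compound 4 is estimated at 4.5 h in this assay, between 2 h and 10 h.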

Compound 4, half-life: 0.3 h
Compound 4: the middle estimate sits 15-fold (1.18 log units) above what was measured, and the stated range ends above it.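

In this assay, methyl in place of chloro on an aromatic carbon, here meta to a chloro group, gives an 8.6-fold lower number from compound 3 to compound 4 (0.93 log units; beyond the scatter). Set beside the earlier step, the same change differs in direction and the two steps do not agree: the same change on two cores in this assay, a 2.4-fold higher number (0.37 log units; beyond the scatter) from compound 1 to compound 2 and an 8.6-fold lower number (0.93 log units; beyond the scatter) from compound 3 to compound 4, 20-fold (1.31 log units) apart, beyond the scatter of two such steps. Within the data shown here, the step on the core of compound 1 is therefore no guide to the step on the core of compound 3, but two pairs do not show whether the gap follows from the place of the change or from the other groups on each core, and they give no rule for any further core.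

Still open, going by these compounds, is how other groups at the place of the chloro group of compound 3, such as a methoxy group, a nitrile or an amine, would read in this assay. Also open, on these data alone, is whether the shorter half-life on going from chloro to methyl recurs on cores beyond that of compound 3.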